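A few compounds are considered here, and "the series" means these few. Any claim that something is new, unique, unknown or untested is made for them only; others in the source may bear on it.

Two compounds in this set carry the same core, each with a benzoyl group on the ring nitrogen. Compound 1 `COc1ccc2c(c1)c(-c1nc3ccccc3n1C(=O)c1ccc(OC)c(OC)c1)cn2C` bears a 3,4-dimethoxyphenyl on that carbonyl carbon, and in a functional assay on MCF7 cells (Homo sapiens) for inhibition, read by MTT assay, with a stated time of 24 h (on this read-out higher numbers stand for weaker inhibition of growth and lower numbers for stronger inhibition of growth), compound 1 gives 6300 nM. Compound 2 `COc1ccccc1C(=O)n1c(-c2cn(C)c3ccc(Br)cc23)nc2ccccc21` carries a 2-methoxyphenyl there instead, together with a bromine on the other ring system, and in this assay compound 2 gives 36200 nM. Of the two numbers, that of compound 2 is the higher, and the gap to compound 1 lies beyond the usual scatter.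

Compound 3 `COc1ccc(C(=O)n2c(-c3cn(C)c4ccc(Br)cc34)nc3ccccc32)cc1OC` keeps the brominated part of compound 2 and changes only the benzoyl side: 3,4-dimethoxyphenyl in place of 2-methoxyphenyl on a carbonyl carbon. For the measured compounds named here, since compound 1, the only measured compound bearing the 3,4-dimethoxyphenyl, gives 6300 nM, a step toward a lower number is expected, though the two compounds also differ elsewhere, so the expected size is modest. The expected step is a 2.8-fold lower number from compound 2 to compound 3 (0.44 log units; beyond the scatter). For compound 3 in this assay the estimate is 13000 nM, ranging from 4000 nM to 40000 nM.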

Compound 3, concentration for 50% growth inhibition: 11300 nM
For compound 3 the middle estimate is 1.2-fold (0.06 log units) above the measured one, within the range that was stated.
By their numbers in this assay, from the lowest: compounds 1 and 3 (each within the scatter of the next); then compound 2.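

For the compounds shown here, with the bromine kept in place, 3,4-dimethoxyphenyl in place of 2-methoxyphenyl on a carbonyl carbon gives a 3.2-fold lower number from compound 2 to compound 3 (0.51 log units; beyond the scatter) in this assay, the first reading of this change on its own and one that lies beyond the scatter. With the 3,4-dimethoxyphenyl kept instead, bromo in place of methoxy on an aromatic carbon gives a 1.8-fold higher number from compound 1 to compound 3 (0.25 log units; within the scatter), which lies within the scatter, so this pair shows no clear effect of that exchange, and of the two places in which compound 1 and compound 2 differ, only the group on the carbonyl carbon has a step beyond the scatter. Nothing available explains why the group on the carbonyl carbon matters here.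

The compounds shown leave open whether the same change would hold with methoxy rather than bromo on the aromatic carbon, and whether both methoxy groups of the 3,4-dimethoxyphenyl are needed for the step. They also leave open how this position would respond to an amine or a carboxylic acid on that phenyl ring, or to a longer chain in place of a methoxy group.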